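The source may hold more compounds than are shown below. What is called first, only, known or untested is meant among the compounds shown, and "the series" means these compounds.

The study concerns two cores examined in an ADME assay on Vero cells (Chlorocebus sabaeus) for cytotoxicity, read by sulforhodamine B assay, with a stated time of 72 h; a higher number here means a weaker inhibitor, a lower number a stronger inhibitor. Compound 1 `CN1CCc2cc(-c3ccccc3)ccc2C1` belongs to the first core. In this assay compound 1 gives > 50000 nM, which is a limit of the assay and not a number. Compound 2 `CN1CCc2cc(-c3ccc(-c4ccccc4)cc3)ccc2C1` differs from it by phenyl in place of hydrogen on an aromatic carbon. In this assay compound 2 gives 15600 nM. The step between them is an at least 3.2-fold lower number from compound 1 to compound 2 (0.50 log units; beyond the scatter), and it can only be stated as a bound because of the limit of > 50000 nM in this assay, at which 1 of the 3 values shown sits. Compound 3 `OC1CN(Cc2ccccc2)Cc2ccc(OCc3ccccc3)cc21` rests on a different core; the difference between the two cores is not broken down here. In this assay compound 3 gives 31800 nM, the higher of the two numbers shown, and its gap to compound 2 lies beyond the scatter. Compound 4 `OC1CN(Cc2ccccc2)Cc2ccc(OCc3ccc(-c4ccccc4)cc3)cc21` has not yet been measured in this assay. It differs from compound 3 by phenyl in place of hydrogen on an aromatic carbon, the same change that separates compound 1 from compound 2, made at a place described in the same words. On this single precedent compound 4 is expected to come in lower than compound 3 by about a 2.9-fold lower number from compound 3 to compound 4 (0.46 log units; beyond the scatter), an expectation that rests on an at least 3.2-fold lower number from compound 1 to compound 2 (0.50 log units; beyond the scatter). Compound 4 is therefore estimated at 11000 nM in this assay, with a likely range from 4000 nM to 30000 nM.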

Compound 4, half-maximal inhibitory concentration: 14800 nM
For compound 4 the middle estimate is 1.3-fold (0.13 log units) below the measured one; measured number inside the range.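

In this assay, phenyl in place of hydrogen on an aromatic carbon also lowers the number on the second core, with a 2.1-fold lower number from compound 3 to compound 4 (0.33 log units; beyond the scatter), and the step is modest but lies beyond the scatter. The change therefore moves the number in the same direction on both cores, though the two steps cannot be separated by size: the same change on two cores in this assay, an at least 3.2-fold lower number (0.50 log units; beyond the scatter) from compound 1 to compound 2 and a 2.1-fold lower number (0.33 log units; beyond the scatter) from compound 3 to compound 4; the limit leaves it open whether they differ This pair of steps does not show that the change is worth the same amount on each core, and two cores do not establish a rule for the whole series, as the earlier step stands only as a bound because one of its ends is a limit and not a number: the limit of > 50000 nM in this assay, at which 1 of the 4 values shown sits.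

The compounds shown leave open whether a different group on the same aromatic carbon, such as a methoxy group, an amine or a carboxylic acid, would shift the number in the same direction as phenyl. They also leave open whether the step would recur on a third core, and whether a longer chain between the rings of the second core would change its size.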